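The source may report more compounds than this note shows. Statements on the series, on what has been measured and on what is new or still open speak of the compounds shown alone.

Measured compounds:
compound 1 `O=C(CN(c1nc(Cl)nc2[nH]cnc12)C1CC1)NCC(=O)OCc1ccccc1` — 27.2%
compound 2 `O=C(O)CC[C@H](NC(=O)CN(c1nc(Cl)nc2[nH]cnc12)C1CC1)C(=O)O` — 44.7%
compound 3 `C[C@H](NC(=O)CN(c1nc(Cl)nc2[nH]cnc12)C1CC1)C(=O)OCc1ccccc1` — 44.2%

In a functional assay on the whole organism (Tail, strain ICR) with Mus musculus as the target, in the tail flick test, with a stated time of 90 min, at a dose of 25 umol/kg by the oral route (on this read-out higher numbers stand for a stronger effect at the one dose given and lower numbers for a weaker effect), compound 2 gives 44.7%, the top of the three numbers, although compound 3 at 44.2% lies within the scatter of it and only compound 1 at 27.2% lies beyond. Compound 4 `CC(C)[C@H](NC(=O)CN(c1nc(Cl)nc2[nH]cnc12)C1CC1)C(=O)O` differs from compound 2 by isopropyl in place of 2-carboxyethyl on a saturated chain carbon bound to an amide-type nitrogen and a carbonyl carbon. Within the data shown here, the one measured step at this place, a number 17 percentage points higher from compound 1 to compound 3 (beyond the scatter), was modest, yet it swapped hydrogen for methyl in a benzyl ester series, not an acid arm for isopropyl in a free acid; it therefore bears on compound 4 only loosely. Compound 4 is expected to stay near compound 2, with a number 2.7 percentage points lower from compound 2 to compound 4 (within the scatter) within the scatter, an estimate of 42% ranging from 25% to 60%.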

Compound 4, a percentage reported as activity, at one dose (the size of the read-out at that dose, not a potency): 30.3%
Estimate against measurement, compound 4: 11.7 percentage points above; the measured number falls inside the stated range.
By their numbers in this assay, from the lowest: compounds 1 and 4 (each within the scatter of the next); then compounds 3 and 2 (each within the scatter of the next).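

The earlier compounds shown here showed this place responding only in benzyl esters, with methyl in place of hydrogen. In this assay, the result shows that it also responds in free acids: isopropyl in place of 2-carboxyethyl gives a number 14.4 percentage points lower from compound 2 to compound 4 (beyond the scatter). Nothing shown here gives a reason for this drop.

As far as these compounds go, it remains open whether the carboxylic acid of the 2-carboxyethyl arm is what matters at this place. A primary amine at the end of the same chain, or a longer chain ending in a carboxylic acid, could settle this.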